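A few compounds are considered here, and "the series" means these few. Any claim that something is new, unique, unknown or untested is made for them only; others in the source may bear on it.

Compound 1 `Cc1cccc(-c2nnc(SCCCN3CCN(c4ccccn4)CC3)[nH]2)c1` gives a limit of > 300000 nM in a functional assay on MCF7 cells (Homo sapiens) for cytotoxicity, read by MTT assay, with a stated time of 24 h; a lower number here means a stronger inhibitor, a higher number a weaker inhibitor.
Compound 2 `CCN1CCN(CCCSc2nnc(-c3ccccc3Cl)[nH]2)CC1` gives a limit of > 300000 nM in this assay.

Both results are limits of the assay rather than numbers, and both sit at the limit of > 300000 nM in this assay, at which 2 of the 2 values shown sit. Compound 2 therefore stands on a limit alone, and the two limits show no difference between compound 1 and compound 2. Compound 3 `Clc1ccccc1-c1nnc(SCCCN2CCN(c3ccccn3)CC2)[nH]1` differs from compound 2 by pyridin-2-yl in place of ethyl on an amine nitrogen in a ring. Among the measured compounds shown here, no measured step covers this change, so no step beyond the scatter is expected. Compound 3 is expected to give 300000 nM, within a range of 100000 nM to 1000000 nM. The expected step is a number no higher from compound 2 to compound 3 (the limit leaves the size open).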

Compound 3, half-maximal inhibitory concentration: > 300000 nM
Compound 3: no number, only a limit; the forecaster's own chance of this, stated with the estimate: 85%; the middle value sits exactly at the limit.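

Among the compounds shown here, compound 3 gives only a limit of the assay, > 300000 nM, so no step from compound 1 or compound 2 to compound 3 can be read. The compounds shown leave open whether pyridin-2-yl in place of ethyl, or 2-chlorophenyl in place of 3-methylphenyl, changes the result at all.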